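Ethoxy to isopropyl on the shared core

A few compounds are considered here, and "the series" means these few. Any claim that something is new, unique, unknown or untested is made for them only; others in the source may bear on it.

Two compounds of this set carry numbers in a functional assay, read by spectrophotometry, with a stated time of 30 min; on this read-out higher numbers stand for weaker inhibition and lower numbers for stronger inhibition. Compound 1 `CCOc1cccc(C(CC)c2ccc(O)c(OC)c2)c1O` gives 7190 nM in this assay. Compound 2 `CCC(c1ccc(O)c(OC)c1)c1ccc(O)cc1O` gives 10100 nM in this assay. Compound 1 holds the lower of the two numbers, but compound 2 stands within the scatter of it, so the two cannot be ranked. Among the measured compounds shown here, compound 2 differs from compound 1 in more than one place, and no single step between measured compounds is available; what the two numbers show is only that both lie in the same region.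

Compound 3 `CCC(c1ccc(O)c(OC)c1)c1cccc(C(C)C)c1O` is not yet measured in this assay. It differs from compound 1 as follows: isopropyl in place of ethoxy on an aromatic carbon. For the measured compounds named here, no measured pair in the set speaks to an exchange of this kind, so the expectation rests on the number for compound 1 alone. The step expected is a 1.1-fold lower number from compound 1 to compound 3 (0.04 log units; within the scatter), none beyond the scatter. Compound 3 is therefore estimated at 6500 nM in this assay, with a range from 2500 nM to 17000 nM that allows for movement in either direction.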

Compound 3, half-maximal inhibitory concentration: 7000 nM
Compound 3: middle estimate off by 1.1-fold (0.03 log units), on the low side; low and high end bracket the measured number.
By their numbers in this assay, from the lowest: compounds 3, 1 and 2 (each within the scatter of the next).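

In this assay, isopropyl in place of ethoxy on the aromatic carbon ortho to a hydroxy group gives a 1.0-fold lower number from compound 1 to compound 3 (0.01 log units; within the scatter) as the only single-place step among the compounds shown, so this pair provides a direct reading at this position that the earlier comparison could not give. The exchange removes the oxygen and its hydrogen-bond acceptor while keeping the count of heavy atoms, and the two numbers cannot be told apart, so at this position in this pair an all-carbon group of that size serves in the same region as ethoxy. No measurement at hand offers any explanation for this result.

From the compounds shown here alone, one pair with two groups of equal heavy-atom count says nothing about how much room for change this position allows, so it remains open whether a longer chain such as n-butoxy, a primary amine or a carboxylic acid on this carbon would hold the same region. The hydroxy group, the methoxy group and the ethyl-bearing link of the shared core also remain without any single-place step of their own.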